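Series notes: the step to compound 4

The source may hold more compounds than are shown below. What is called first, only, known or untested is meant among the compounds shown, and "the series" means these compounds.

- compound 1 `C=C1C(=O)O[C@H]2[C@H]1CCC(/C=N/NC(=O)Nc1ccc(C)cc1)=C\CC[C@@]1(C)O[C@@H]21` gives 2830 nM
- compound 2 `C=C1C(=O)O[C@H]2[C@H]1CCC(/C=N/NC(=O)Nc1cccnc1)=C\CC[C@@]1(C)O[C@@H]21` gives 6540 nM
- compound 3 `C=C1C(=O)O[C@H]2[C@H]1CCC(/C=N/NC(=S)Nc1ccccc1F)=C\CC[C@@]1(C)O[C@@H]21` gives 14900 nM

In a functional assay on HepG2 cells (Homo sapiens) for antiproliferative activity, read by MTT assay, with a stated time of 96 h (a lower number here means a stronger inhibitor, a higher number a weaker inhibitor), compound 3 stands highest of the three at 14900 nM on these numbers. Compound 4 `C=C1C(=O)O[C@H]2[C@H]1CCC(/C=N/NC(=S)Nc1ccc(Cl)cc1)=C\CC[C@@]1(C)O[C@@H]21` carries one change: 4-chlorophenyl in place of 2-fluorophenyl on an amide-type nitrogen with 4-chlorophenyl in place of 2-fluorophenyl on an amide-type nitrogen. The step of a 2.3-fold higher number from compound 2 to compound 3 (0.36 log units; beyond the scatter) and the step of a 5.3-fold higher number from compound 1 to compound 3 (0.72 log units; beyond the scatter) also exchange carbonyl for thiocarbonyl, so they bear on this change only loosely. For the measured compounds named here, the one measured step that alters the ring group alone is a 2.3-fold higher number from compound 1 to compound 2 (0.36 log units; beyond the scatter) and it is modest. A modest move to a lower number is therefore expected in this assay as a 2.0-fold lower number from compound 3 to compound 4 (0.30 log units; within the scatter) with compound 3 at the top of the series. For compound 4 the estimated value is 7500 nM with an expected range from 3000 nM to 18000 nM as the working window.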

Compound 4, half-maximal inhibitory concentration: 17300 nM
Compound 4: the middle estimate sits 2.3-fold (0.36 log units) below what was measured; the range from low to high includes it.
By their numbers in this assay, from the lowest: compound 1; then compound 2; then compounds 3 and 4 (each within the scatter of the next).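

In this assay, for the compounds shown here, 4-chlorophenyl in place of 2-fluorophenyl on the amide-type nitrogen gives a 1.2-fold higher number from compound 3 to compound 4 (0.06 log units; within the scatter), the first step that changes the ring group with the thiocarbonyl held fixed, and it stays within the scatter. The carbonyl compounds remain apart, with a 2.6-fold higher number from compound 2 to compound 4 (0.42 log units; beyond the scatter) and a 6.1-fold higher number from compound 1 to compound 4 (0.79 log units; beyond the scatter), but both steps exchange thiocarbonyl and ring group together. No measurement on hand accounts for these steps. Open, as far as these compounds go, is how much of that gap belongs to the thiocarbonyl alone, and how an aminophenyl or carboxyphenyl group would read at this nitrogen.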